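This account rests on a few compounds, and the source may have more. Where it says the series, first, only, none or still open, it means among the compounds named here.

Compound 3 `Cc1cccc(Cn2c(CN3CCN(C(=O)C4CCCCC4)CC3)nc3ccccc32)c1` stands second highest of the three numbers measured in an assay on isolated protein for inhibition of aldehyde dehydrogenase 1A1 (Homo sapiens), read by spectrophotometry, tested at 10 uM (on this read-out lower numbers stand for less inhibition and higher numbers for more inhibition at the one concentration tested (going by the name of the read-out)), where compound 3 gives 31.9%. Compound 1 `Cc1cccc(Cn2c(CN3CCN(C(=O)c4ccc([N+](=O)[O-])cc4)CC3)nc3ccccc32)c1` gives 24.3%, and compound 2 `CCC(=O)N1CCN(Cc2nc3ccccc3n2Cc2cccc(C)c2)CC1` gives 85.1%. The step of a number 60.8 percentage points higher from compound 1 to compound 2 (beyond the scatter) was large, as was the step of a number 53.2 percentage points lower from compound 2 to compound 3 (beyond the scatter), while the step of a number 7.6 percentage points higher from compound 1 to compound 3 (within the scatter) stayed within the scatter.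

Compound 4 `Cc1cccc(Cn2c(CN3CCN(C(=O)c4ccc(Cl)cc4)CC3)nc3ccccc32)c1` differs from compound 3 in one place: 4-chlorophenyl in place of cyclohexyl on a carbonyl carbon. Among the measured compounds shown here, no measured step swaps cyclohexyl for 4-chlorophenyl on a carbonyl carbon, so the forecast rests on the neighbouring comparison. Compound 1 carries 4-nitrophenyl on that same carbonyl carbon, and its number sits within the scatter of compound 3. On that basis a step of about a number 1.9 percentage points lower from compound 3 to compound 4 (within the scatter) is expected for compound 4, meaning no change beyond the scatter. Compound 4 is estimated at 30%, with a range from 10% to 55%.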

Compound 4, a percentage reported as inhibition, at one concentration (the size of the read-out at that concentration, not a potency): 23.2%
Estimate against measurement, compound 4: 6.8 percentage points above; low and high end bracket the measured number.
By their numbers in this assay, from the lowest: compounds 4, 1 and 3 (each within the scatter of the next); then compound 2.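

In this assay, a step of a number 8.7 percentage points lower from compound 3 to compound 4 (within the scatter) shows that an aromatic 4-chlorophenyl and a non-aromatic cyclohexyl on this carbonyl carbon cannot be told apart, and a step of a number 1.1 percentage points lower from compound 1 to compound 4 (within the scatter) shows the same for chloro and nitro on the aromatic ring. A step of a number 61.9 percentage points lower from compound 2 to compound 4 (beyond the scatter) adds a third ring-bearing group that stands far from ethyl, so among these four compounds 1, 3 and 4 form one group and compound 2 alone stands apart. No measurement shown here explains why the ethyl compound differs from the others.

On these data alone, it remains open whether the high number of compound 2 belongs to ethyl alone or extends to methyl, propyl or cyclopropyl on the same carbonyl carbon. As far as these compounds go, it is equally open whether an amine or a carboxylic acid on the aromatic ring would keep compound 4's number.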